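Adding a Second Chloro to a Purine Cytotoxic Agent

A few compounds are considered here, and "the series" means these few. Any claim that something is new, unique, unknown or untested is made for them only; others in the source may bear on it.

Compound 1 `ClCc1ccccc1Cn1cnc2c(Cl)nc(Cl)nc21` was included in this study, but in a functional assay on COLO 205 cells (Homo sapiens) for cytotoxicity, read by sulforhodamine B assay, with a stated time of 48 h (a higher number here means a weaker inhibitor of growth, a lower number a stronger inhibitor of growth), compound 1 gives "not determined" (no result reported), that is, no result for it was reported. For the measured compounds named here, compound 2 `ClCc1cccc(Cn2cnc3ncnc(Cl)c32)c1` therefore provides the only number in hand: in this assay compound 2 gives 2630 nM. With a single measured compound there is no comparison available, so compound 2 cannot be ranked against anything.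

Compound 3 `ClCc1cccc(Cn2cnc3nc(Cl)nc(Cl)c32)c1` is the next step. It differs from compound 2 in one place: chloro in place of hydrogen on an aromatic carbon. Going by the values given here, no measured pair shows what this kind of change does to growth inhibition, so the expectation rests only on the general observation that such a small substitution usually moves the value modestly. This estimate means a step of a 1.5-fold lower number from compound 2 to compound 3 (0.16 log units; within the scatter), expected to fall within the usual scatter or to bring a slight gain in potency. Compound 3 is expected to give 1800 nM, with a range from 500 nM to 6500 nM.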

Compound 3, concentration for 50% growth inhibition: 410 nM
Compound 3: middle estimate off by 4.4-fold (0.64 log units), on the high side; the whole stated range lies above it.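

In this assay, chloro in place of hydrogen on the aromatic carbon between two ring nitrogen atoms gives a 6.4-fold lower number from compound 2 to compound 3 (0.81 log units; beyond the scatter), so a stronger inhibitor of growth. For the compounds shown here, this is the first measured sign that this position of the core responds to a change, and that adding one heavy atom there can move the value beyond the usual scatter. No available evidence accounts for this gain.

On these data alone, this single pair compares only hydrogen and chloro, so it remains open whether the gain is particular to chloro or would also appear with an amine, a methoxy group or a longer chain at the same carbon. As far as these compounds go, it also remains open whether the gain carries over to compounds that differ elsewhere, and compound 1, with no reported result, cannot answer that.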